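Methoxy for amino on the aryl ketone of compound 1

This account rests on a few compounds, and the source may have more. Where it says the series, first, only, none or still open, it means among the compounds named here.

Going by the values given here, compound 1 `COc1cc(-c2cc(/C=C/C(=O)c3ccc(N)cc3)[nH]n2)cc(OC)c1OC` gives in a functional assay on SF-268 cells (Homo sapiens) for inhibition, read by sulforhodamine B assay, with a stated time of 48 h (on this read-out higher numbers stand for weaker inhibition of growth and lower numbers for stronger inhibition of growth), a value of 3930 nM, the lowest of the two numbers measured so far; nearest stands compound 2 `COc1ccc(-c2cc(/C=C/C(=O)c3ccc(N)cc3)[nH]n2)cc1OC` at 4400 nM. Among the compounds with values here, the single measured step, a 1.1-fold higher number from compound 1 to compound 2 (0.05 log units; within the scatter), concerns hydrogen in place of methoxy on an aromatic carbon of the other aromatic ring and lies within the scatter, so neither compound can be called stronger than the other.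

Compound 3 `COc1ccc(C(=O)/C=C/c2cc(-c3cc(OC)c(OC)c(OC)c3)n[nH]2)cc1` differs from compound 1 as follows: methoxy in place of amino on an aromatic carbon. The amino group leaves and a methoxy group enters on the same aromatic carbon, para to a large group, so that the 4-aminophenyl becomes a 4-methoxyphenyl. Within the data shown here, no measured step touches this position; the one step available lies on the other ring and was within the scatter. There is no basis for expecting a step beyond the scatter in this assay, and the estimate carries a wide range. The expected step is a 1.1-fold higher number from compound 1 to compound 3 (0.06 log units; within the scatter). Compound 3 is estimated at 4500 nM, between 1500 nM and 15000 nM.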

Compound 3, concentration for total growth inhibition: 5120 nM
Compound 3: the middle estimate sits 1.1-fold (0.06 log units) below what was measured; low and high end bracket the measured number.
By their numbers in this assay, from the lowest: compounds 1, 2 and 3 (each within the scatter of the next).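

With this step the position on the aryl ketone has its first measured change: in this assay the exchange of the 4-aminophenyl for the 4-methoxyphenyl gives a 1.3-fold higher number from compound 1 to compound 3 (0.11 log units; within the scatter). The earlier step concerned only the other aromatic ring, so this pair adds that the aromatic carbon para to a large group can carry either amino or methoxy without a difference beyond the scatter, even though amino has a hydrogen-bond donor and methoxy has none; this holds for this one pair and this one read-out. Nothing available explains why the two groups read alike here.

Open, as far as these compounds go, is whether a hydroxyl, a dimethylamino group, a carboxylic acid or a longer alkoxy chain on the same carbon would also stay within the scatter of compound 1, or whether only some groups at this position would give a step beyond it. Also open, from the compounds shown here alone, is whether the exchange of amino for methoxy reads the same on compound 2, where the other aromatic ring carries one methoxy group fewer.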